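Benzyloxy in Place of Nitro on the Shared Core

The compounds below may be only part of what the source reports. "The series", "measured", "known", "first", "only" and "open" are said of these compounds alone.

Of the compounds shown here, three have been measured in an assay on HeLa cells for binding affinity to 5-hydroxytryptamine receptor 6 (Homo sapiens); a lower number here means a stronger inhibitor, a higher number a weaker inhibitor. Compound 1 `Nc1ccc(S(=O)(=O)n2cc(C3=CCNCC3)c3cc([N+](=O)[O-])ccc32)cc1` gives 29 nM, the second highest of the three numbers. Compound 2 `Nc1ccc(S(=O)(=O)n2cc(C3=CCNCC3)c3ccc([N+](=O)[O-])cc32)cc1` gives 31 nM, which lies within the scatter of compound 1. Compound 3 `O=S(=O)(c1nccc2sncc12)n1cc(C2=CCNCC2)c2ccccc21` gives 5 nM, a lower number than compound 1 by more than the scatter. Compound 4 `Nc1ccc(S(=O)(=O)n2cc(C3=CCNCC3)c3cc(OCc4ccccc4)ccc32)cc1` has not yet been measured in this assay and differs from compound 1 in one place: benzyloxy in place of nitro on an aromatic carbon. No measured pair shows the same change, so nothing shown fixes the direction of the step. The expectation is a step of a 1.4-fold higher number from compound 1 to compound 4 (0.14 log units; within the scatter), close to no change beyond the scatter. Compound 4 is estimated at 40 nM, with a range from 10 nM to 160 nM.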

Compound 4, inhibition constant: 50 nM
Compound 4: the middle estimate sits 1.3-fold (0.10 log units) below what was measured; the range from low to high includes it.
By their numbers in this assay, from the lowest: compound 3; then compounds 1, 2 and 4 (each within the scatter of the next).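

In this assay, benzyloxy in place of nitro on this aromatic carbon gives a 1.7-fold higher number from compound 1 to compound 4 (0.24 log units; within the scatter), so the step stays within the scatter. This position of the shared core therefore holds a larger group carrying its own six-membered aromatic ring, with no change in the number that can be told from the scatter. Nothing shown gives a measured reason for this result. From the compounds shown here alone, whether an amine or a carboxylic acid on this carbon would also stay within the scatter of compound 1 remains open, as does whether benzyloxy would do so in place of the nitro of compound 2.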